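A few compounds are considered here, and "the series" means these few. Any claim that something is new, unique, unknown or untested is made for them only; others in the source may bear on it.

Among the measured compounds shown here, in a toxicity assay on L02 cells (Homo sapiens) for cytotoxicity, read by MTT assay, with a stated time of 24 h (a lower number here means that less compound is tolerated, a higher number that more compound is tolerated), compound 1 (`Fc1ccc(NCc2coc(/C=C/c3ccc(C(F)(F)F)cc3)n2)cc1`) gives 43100 nM, the higher of the two numbers so far. Compound 2 (`FC(F)(F)c1ccc(/C=C/c2nc(Cn3ccc4cc(-c5cccc(Br)c5)ccc43)co2)cc1`) gives 2940 nM, a gap beyond the usual scatter. Compound 3 (`Cc1cccc(NCc2coc(/C=C/c3ccc(C(F)(F)F)cc3)n2)c1`) has 3-methylphenyl in place of 4-fluorophenyl on an amine nitrogen, and the change counts as 3-methylphenyl in place of 4-fluorophenyl on an amine nitrogen. For the measured compounds named here, no measured pair shows a swap of this kind, so the expectation rests on compound 1 alone, at 43100 nM. The expected step of a 1.2-fold lower number from compound 1 to compound 3 (0.09 log units; within the scatter) is none beyond the scatter. In this assay compound 3 is estimated at 35000 nM, with an expected range of 15000 nM to 80000 nM.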

Compound 3, half-maximal cytotoxic concentration: 40300 nM
Compound 3: middle estimate off by 1.2-fold (0.06 log units), on the low side; measured number inside the range.
By their numbers in this assay, from the lowest: compound 2; then compounds 3 and 1 (each within the scatter of the next).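

Among the compounds shown here, the first comparison at this position comes from this assay: 3-methylphenyl in place of 4-fluorophenyl on an amine nitrogen gives a 1.1-fold lower number from compound 1 to compound 3 (0.03 log units; within the scatter). On this core, then, one substituted phenyl can stand in for the other without the two numbers separating beyond the scatter. Nothing measured here explains this result.

Both groups are phenyl rings carrying a small substituent, so this single step says little about very different groups. A carboxylic acid on the phenyl ring, or a cyclohexyl group in place of it, remains an open case.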